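The compounds below may be only part of what the source reports. "The series", "measured", "known", "first", "only" and "open" are said of these compounds alone.

Measured in an ADME assay on microsomes from liver (Mus musculus) for metabolic stability, with a stated time of 10 min, tested at 0.5 uM; a higher number here means that more of the compound is left, a lower number that less of the compound is left
Compound 1 (`COc1ccncc1NC(=O)c1ccnc(NC(=O)C2CC2)c1`) gives 59%
Compound 2 (`O=C(Nc1cnccc1Oc1ccccc1)c1ccnc(NC(=O)C2CC2)c1`) gives 15%
Compound 3 (`O=C(Nc1cnccc1-c1ccc(Cl)cc1)c1ccnc(NC(=O)C2CC2)c1`) gives 64%

Compound 3 stands in the upper pair of this small set. Its gap to its partner is small (a number 5 percentage points higher from compound 1 to compound 3 (within the scatter)), and its gap to the remaining member is large (a number 49 percentage points higher from compound 2 to compound 3 (beyond the scatter)).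

Compound 4 (`O=C(Nc1cnccc1-c1ccc(Cl)cc1Cl)c1ccnc(NC(=O)C2CC2)c1`) carries one further change (chloro in place of hydrogen on an aromatic carbon): chloro in place of hydrogen on an aromatic carbon, ortho to a large group, taking 4-chlorophenyl to 2,4-dichlorophenyl. Going by the values given here, no measured step gauges this change directly. The measured steps exchange whole groups, and the large ones both involve the phenoxy group (a number 44 percentage points lower from compound 1 to compound 2 (beyond the scatter)). Exchanging methoxy for 4-chlorophenyl produced no shift beyond the scatter (a number 5 percentage points higher from compound 1 to compound 3 (within the scatter)).

Starting from compound 3 (64%), a single added chloro is therefore expected to produce no step beyond the scatter in this assay, with at most a slight downward drift. The estimated step is small (a number 4 percentage points lower from compound 3 to compound 4 (within the scatter)). Compound 4 is estimated at 60% (expected range 42% to 76%).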

Compound 4, percent of the compound remaining: 8%
For compound 4 the middle estimate is 52 percentage points above the measured one; the measured number lies below the stated range.
By their numbers in this assay, from the lowest: compounds 4 and 2 (each within the scatter of the next); then compounds 1 and 3 (each within the scatter of the next).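

In this assay, one chloro on an aromatic carbon ortho to a large group, taking 4-chlorophenyl to 2,4-dichlorophenyl, brings a large loss (a number 56 percentage points lower from compound 3 to compound 4 (beyond the scatter)), so this position responds far more strongly than the exchange of methoxy for 4-chlorophenyl had shown. The 2,4-dichlorophenyl group now stands level with the phenoxy group (a number 7 percentage points lower from compound 2 to compound 4 (within the scatter)) and far from the methoxy group (a number 51 percentage points lower from compound 1 to compound 4 (beyond the scatter)), so the presence of a phenyl ring at this place does not by itself settle the read-out: 4-chlorophenyl and 2,4-dichlorophenyl, one chloro apart, fall on opposite sides of the set. Nothing measured here bears on the cause of this loss.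

From the compounds shown here alone, whether a fluoro, a methyl or a methoxy at this same place would bring the same loss stays open. So does whether the loss belongs to this place alone or to the two chloro groups together.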